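This account rests on a few compounds, and the source may have more. Where it says the series, first, only, none or still open, it means among the compounds named here.

Measured in a functional assay on DU-145 cells (Homo sapiens) for inhibition, read by trypan blue exclusion, with a stated time of 96 h; on this read-out lower numbers stand for stronger inhibition of growth and higher numbers for weaker inhibition of growth:

- Compound 1 `CSc1ccc(/C=C(\C(=O)c2ccc(Cl)cc2)S(=O)(=O)Cc2ccc(C)cc2)cc1`: 10000 nM
- Compound 2 `COc1cc(/C=C(/SCc2ccc(Br)cc2)C(=O)c2ccc(C(=O)O)cc2)ccc1F`: 1000 nM

Only these two numbers are available so far. Compound 1 stands at the higher of them, which makes it the weaker growth inhibitor of the pair. Compound 2 has the lower number, and the gap between them lies beyond the usual scatter. The two compounds differ in more than one place, so this gap cannot be tied to any single structural change.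

The next compound, compound 3 `Cc1ccc(CS(=O)(=O)/C(=C/c2c[nH]c3ccccc23)C(=O)c2ccc(Cl)cc2)cc1`, keeps the core of compound 1 and changes one group: 1H-indol-3-yl stands in place of 4-(methylsulfanyl)phenyl on a double-bonded chain carbon bound to a double-bonded chain carbon (1H-indol-3-yl in place of 4-(methylsulfanyl)phenyl on a double-bonded chain carbon bound to a double-bonded chain carbon). Within the data shown here, no measured pair shows what this swap does, so any forecast is loose. Since compound 1 at 10000 nM is the higher of the two numbers, a moderate step toward stronger inhibition in this assay is expected, though a result within the scatter remains possible. The estimated step is a 3.3-fold lower number from compound 1 to compound 3 (0.52 log units; beyond the scatter). The estimate for compound 3 is 3000 nM, with an expected range of 500 nM to 10000 nM.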

Compound 3, concentration for 50% growth inhibition: 25000 nM
Beside the measured number, compound 3's estimate is 8.3-fold (0.92 log units) below it; measured number outside the range, above it.
By their numbers in this assay, from the lowest: compound 2; then compound 1; then compound 3.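

In this assay, 1H-indol-3-yl in place of 4-(methylsulfanyl)phenyl on a double-bonded chain carbon bound to a double-bonded chain carbon gives a 2.5-fold higher number from compound 1 to compound 3 (0.40 log units; beyond the scatter), a modest loss of growth inhibition. Among these compounds, this is the first comparison here in which only one place changes, so it shows that growth inhibition responds to the group at this position, and that this swap weakens inhibition rather than strengthening it. The swap alters several things at once, adding a five-membered aromatic ring and a hydrogen-bond donor while removing the sulfur and a hydrogen-bond acceptor, and no measurement available here explains the loss or shows which of these alterations matters.

A single swap cannot show how this position responds more broadly, and a plain phenyl ring or a phenyl ring carrying an amine would help separate the contribution of the methylsulfanyl group from that of the aromatic ring itself. As far as these compounds go, it also remains open whether the same swap would have a similar effect on the differently built compound 2.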